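The source may hold more compounds than are shown below. What is called first, only, known or untested is meant among the compounds shown, and "the series" means these compounds.

Working notes on the series. Compound 1 `Cn1cnc(S(=O)(=O)N2C[C@@H]3[C@H](C2)[C@@]3(CNC(=O)c2cc(Cl)cc(Cl)c2)CC2CC2)c1` gives 100 nM in an assay on isolated protein for inhibition of sodium- and chloride-dependent glycine transporter 1 (Homo sapiens) (on this read-out lower numbers stand for stronger inhibition and higher numbers for weaker inhibition), the lowest of the two numbers recorded so far. Compound 2 `O=C(NC[C@]1(CC2CC2)[C@@H]2CN(S(=O)(=O)CC3CC3)C[C@@H]21)c1ccc(Cl)cc1Cl` stands next, with 230 nM, a gap beyond the usual scatter. Compound 3 `Cn1cnc(S(=O)(=O)N2C[C@@H]3[C@H](C2)[C@@]3(CNC(=O)c2cccc(C(F)(F)F)c2)CC2CC2)c1` is not yet measured; it differs from compound 1 by 3-(trifluoromethyl)phenyl in place of 3,5-dichlorophenyl on a carbonyl carbon. Going by the values given here, no step between measured compounds covers this change, so the expected size rests on compound 1 alone. A moderate loss is expected, a 2.5-fold higher number from compound 1 to compound 3 (0.40 log units; beyond the scatter), somewhat beyond the scatter. For compound 3 the estimate is 250 nM, with a range from 80 nM to 800 nM.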

Compound 3, half-maximal inhibitory concentration: 64 nM
Estimate against measurement, compound 3: 3.9-fold (0.59 log units) above; measured number below the stated range.
By their numbers in this assay, from the lowest: compounds 3 and 1 (each within the scatter of the next); then compound 2.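

In this assay, going by these compounds alone, a 1.6-fold lower number from compound 1 to compound 3 (0.19 log units; within the scatter) gives the first reading at this position on a carbonyl carbon, and it leaves the two aryl groups within the scatter of each other. On the core of compound 1, 3-(trifluoromethyl)phenyl therefore serves as well as 3,5-dichlorophenyl in this assay. Nothing at hand gives a reason for this match.

From the compounds shown here alone, whether a phenyl ring bearing a carboxylic acid or an amine, or a pyridine ring, would hold at this position remains open. So does whether this match carries over to the sulfonyl group of compound 2.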